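The source may report more compounds than this note shows. Statements on the series, on what has been measured and on what is new or still open speak of the compounds shown alone.

Working notes on the series, read in a functional assay on HL-60 cells (Homo sapiens) for antiproliferative activity, read by MTT assay, with a stated time of 48 h; a lower number here means a stronger inhibitor, a higher number a weaker inhibitor. Compound 1 `CC(=O)OC/C1=C/C[C@](C)(CCC=C(C)C)/C=C/[C@@H](OC(=O)C=C(C)C)[C@](C)(O)/C=C/C1=O` gives 2950 nM. Going by the values given here, compound 2 `CC(C)=CCC[C@]1(C)/C=C/[C@@H](OC(=O)C=C(C)C)[C@](C)(O)/C=C/C(=O)/C(CN2CCCC2)=C\C1` gives 160 nM, the lower of the two numbers measured so far. Compound 3 `CC(C)=CCC[C@]1(C)/C=C/[C@@H](OC(=O)C=C(C)C)[C@](C)(O)/C=C/C(=O)/C(CN=[N+]=[N-])=C\C1` has not yet been measured. The change leading to it is azido in place of pyrrolidin-1-yl on a saturated chain carbon bound to a double-bonded ring carbon.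

Among the compounds with values here, one measured step bears on this place: an 18-fold lower number from compound 1 to compound 2 (1.27 log units; beyond the scatter), a large step beyond the scatter, with pyrrolidin-1-yl in place of acetoxy. Within the data shown here, no measured compound carries azido, so this single step is the only guide. Compound 3 no longer carries pyrrolidin-1-yl, so a move back toward compound 1 at 2950 nM is expected, recovering much of that large step but not necessarily all of it. The expected step is a 7.5-fold higher number from compound 2 to compound 3 (0.88 log units; beyond the scatter), upward and beyond the scatter. For compound 3 the estimated value is 1200 nM, with an expected range of 350 nM to 4000 nM.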

Compound 3, half-maximal inhibitory concentration: 910 nM
Compound 3: middle estimate off by 1.3-fold (0.12 log units), on the high side; measured number inside the range.
By their numbers in this assay, from the lowest: compound 2; then compound 3; then compound 1.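

In this assay, the azido group on a saturated chain carbon bound to a double-bonded ring carbon gives two readings: against pyrrolidin-1-yl there is a 5.7-fold higher number from compound 2 to compound 3 (0.75 log units; beyond the scatter) and against acetoxy there is a 3.2-fold lower number from compound 1 to compound 3 (0.51 log units; beyond the scatter). This places azido between the other two groups and shows that a lower number than that of the acetoxy compound does not require the pyrrolidin-1-yl ring, although among these three compounds the lowest number still belongs to the compound carrying that ring. No measurement offered here explains this order of the three groups.

With only three groups at this place, the compounds shown cannot tell whether the advantage of compound 2 over compound 3 follows the ring nitrogen, the ring itself, or the carbon atoms that pyrrolidin-1-yl brings. Piperidin-1-yl, morpholin-4-yl or an open-chain dimethylamino group on the same carbon would separate these readings, and a plain hydroxyl there would show how much of the difference from acetoxy remains without any nitrogen.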